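Fluorophenyl Position Swap in Two Enone Series Against WiDr Cells

The source may report more compounds than this note shows. Statements on the series, on what has been measured and on what is new or still open speak of the compounds shown alone.

Measured compounds:
Compound 1 `CC(=O)OC/C(=C\c1ccc(F)cc1)C(=O)c1ccccc1`: 13000 nM
Compound 2 `CC(=O)OC/C(=C\c1ccccc1F)C(=O)c1ccccc1`: 19000 nM
Compound 3 `C=C(C/C(=C\c1ccc(F)cc1)C(=O)c1ccccc1)C(=O)c1ccccc1`: 19000 nM

All three were tested in a functional assay on WiDr cells (Homo sapiens) for inhibition, read by sulforhodamine B assay, with a stated time of 48 h; a lower number here means a stronger inhibitor of growth, a higher number a weaker inhibitor of growth. Compound 1 and compound 2 share one core; compound 3 carries a different core, and the difference between the two cores is not broken down here. Compound 3 and compound 2 give the same number at the digits shown, and compound 3 stands within the scatter of compound 1 as well, so no order among the three can be claimed.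

The change from compound 1 to compound 2 is 2-fluorophenyl in place of 4-fluorophenyl on a double-bonded chain carbon bound to a double-bonded chain carbon and gave a 1.5-fold higher number from compound 1 to compound 2 (0.16 log units; within the scatter). Compound 4 `C=C(C/C(=C\c1ccccc1F)C(=O)c1ccccc1)C(=O)c1ccccc1` is not yet measured; it arises from compound 3 by 2-fluorophenyl in place of 4-fluorophenyl on a double-bonded chain carbon bound to a double-bonded chain carbon, the same change in the same place. Since the change moved compound 1 to compound 2 only within the scatter, the step from compound 3 to compound 4 is expected to be of similar small size, a 1.3-fold higher number from compound 3 to compound 4 (0.12 log units; within the scatter), resting on that single earlier step and on compound 3 at 19000 nM. Compound 4 is therefore expected to give about 25000 nM in this assay, estimated between 12000 nM and 55000 nM.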

Compound 4, concentration for 50% growth inhibition: 17000 nM
Estimate against measurement, compound 4: 1.5-fold (0.17 log units) above; the range from low to high includes it.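

On the core of compound 3, 2-fluorophenyl in place of 4-fluorophenyl gave a 1.1-fold lower number from compound 3 to compound 4 (0.05 log units; within the scatter) in this assay. Set beside the same change on the core of compound 1, this step does not differ from the earlier one: the same change on two cores in this assay, a 1.5-fold higher number (0.16 log units; within the scatter) from compound 1 to compound 2 and a 1.1-fold lower number (0.05 log units; within the scatter) from compound 3 to compound 4, 1.6-fold (0.21 log units) apart, within the scatter of two such steps. The change therefore carried from one core to the other in the limited sense that it left the number within the scatter on both, but neither step shows a real effect of the swap, a shared direction cannot be claimed, and two pairs say nothing about how it would behave on any further core.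

Left open is whether a different group in place of the fluorine, such as a chlorine, a methoxy group or a dimethylamino group, would move the number beyond the scatter on either core. As far as these compounds go, it also remains open whether the swap would stay this small on a core carrying an amine or a carboxylic acid in its chain.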